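Oxadiazole ethers against Mythimna separata: compound 3 projection

A few compounds are considered here, and "the series" means these few. Any claim that something is new, unique, unknown or untested is made for them only; others in the source may bear on it.

Measured so far:
- compound 1, `Cc1ccc(-c2nnc(COc3cnn(C(C)(C)C)c(=O)c3Cl)o2)cc1`: 19.9 ug/mL
- compound 2, `CCCCn1ncc(OCc2nnc(-c3ccccc3)o2)c(Cl)c1=O`: > 300 ug/mL

Going by the values given here, in a functional assay on the whole organism for inhibition, with Mythimna separata as the target, with a stated time of 5 days (a lower number here means that less compound is needed, a higher number that more compound is needed for the effect), compound 1 gives 19.9 ug/mL, the only actual number in the set. Compound 2 reaches only a limit of the assay, > 300 ug/mL. That limit, (the limit of > 300 ug/mL in this assay, at which 1 of the 2 values shown sits), is where one of the two values sits. Among the compounds with values here, compound 1 and compound 2 differ in more than one place, so no single step between them can be read, and nothing is known about how much a change on the aryl ring alone is worth.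

The next compound, compound 3, `CC(C)(C)n1ncc(OCc2nnc(-c3cc(F)c(F)cc3F)o2)c(Cl)c1=O`, keeps the core of compound 1 and changes 2,4,5-trifluorophenyl in place of 4-methylphenyl on an aromatic carbon. Within the data shown here, no measured step supports a direction here. Compound 3 is expected to stay near compound 1, with any step from compound 1 to compound 3 likely within or only slightly beyond the scatter, in either direction. Compound 3 is estimated at 25 ug/mL, between 6 ug/mL and 120 ug/mL. The expected step is a 1.3-fold higher number from compound 1 to compound 3 (0.10 log units; within the scatter).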

Compound 3, half-maximal effective concentration: 75.7 ug/mL
Beside the measured number, compound 3's estimate is 3.0-fold (0.48 log units) below it, and the stated range covers the measured number.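

In this assay, the position on the five-membered aromatic ring now has its first readable step: 2,4,5-trifluorophenyl in place of 4-methylphenyl gives a 3.8-fold higher number from compound 1 to compound 3 (0.58 log units; beyond the scatter), so this exchange is not neutral on the core of compound 1, although the step is modest. The change does not abolish the effect, as compound 3 still gives a real number, 75.7 ug/mL, and not a limit of the assay, so a fluorinated aryl ring with more heavy atoms is tolerated here at a cost. No measured property of either aryl group is available to account for this step.

Compound 2 stands at a limit of the assay, > 300 ug/mL, and differs from the other compounds in more than one place, so steps to it cannot be read. Open, from the compounds shown here alone, is whether the step follows from the loss of the methyl group or from the three fluorines, and whether a single fluorine, a methoxy group or a nitrile on this aryl ring would give a number closer to that of compound 1 or to that of compound 3.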